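A few compounds are considered here, and "the series" means these few. Any claim that something is new, unique, unknown or untested is made for them only; others in the source may bear on it.

Measured in a functional assay on PC-3 cells (Homo sapiens) for cytotoxicity, read by MTT assay, with a stated time of 72 h; a lower number here means a stronger inhibitor, a higher number a weaker inhibitor:

Compound 1 `Cc1cccc(-c2ccnc(C(=O)Nc3ccc(Oc4ccnc5[nH]ccc45)cc3)c2)c1`: 5470 nM
Compound 2 `O=C(Nc1ccc(Oc2ccnc3[nH]ccc23)c(F)c1)c1cc(-c2ccccc2)ccn1`: > 10000 nM, a limit of the assay and not a number
Compound 3 `Cc1cccc(-c2ccnc(C(=O)Nc3ccc(Oc4ccnc5[nH]ccc45)c(F)c3)c2)c1`: 860 nM

Compound 3 holds the lowest number of the three in this assay. Its nearest neighbour is compound 1, and the gap appears as a 6.4-fold lower number from compound 1 to compound 3 (0.80 log units; beyond the scatter). That fluoro change is not at stake in what follows, since the fluoro stays in place.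

Compound 4 `Cc1ccc(-c2ccnc(C(=O)Nc3ccc(Oc4ccnc5[nH]ccc45)c(F)c3)c2)c(C)c1` keeps the core of compound 3 and changes only the aryl group: 2,4-dimethylphenyl in place of 3-methylphenyl on an aromatic carbon. The measured step closest to this change is an at least 11-fold lower number from compound 2 to compound 3 (1.06 log units; beyond the scatter), where a methyl in place of hydrogen on an aromatic carbon made a large difference. It shows that this group can matter, but it is a single case, and it does not test a 2,4-dimethylphenyl group. Among the measured compounds shown here, no measured compound carries that group, so the direction is uncertain. Only a slight move toward a higher number is expected, probably not beyond the scatter, though a larger loss remains possible. The expected step is a 1.5-fold higher number from compound 3 to compound 4 (0.18 log units; within the scatter).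

For compound 4 the estimate is 1300 nM, with an expected range of 400 nM to 5000 nM.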

Compound 4, half-maximal inhibitory concentration: 4010 nM
For compound 4 the middle estimate is 3.1-fold (0.49 log units) below the measured one; measured number inside the range.
By their numbers in this assay, from the lowest: compound 3; then compounds 4 and 1 (each within the scatter of the next). At a limit, above all of these: compound 2.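

Among the compounds shown here, the position opposite the ring nitrogen proves more sensitive to the shape of the substituted aryl group than the earlier compounds could show. In this assay, the earlier step showed only that adding a methyl to the phenyl group could lower the number, whereas this change shows that a methyl-bearing aryl group does not guarantee keeping that gain: a 4.7-fold higher number from compound 3 to compound 4 (0.67 log units; beyond the scatter). The 2,4-dimethylphenyl group still stands on the lower side of plain phenyl, an at least 2.4-fold lower number from compound 2 to compound 4 (0.39 log units; beyond the scatter), although compound 2 gives a limit of the assay and not a number, so the true size of that step stays unknown: the limit of > 10000 nM in this assay, at which 1 of the 4 values shown sits.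

The compounds shown do not separate the contributions of the two methyl groups in 2,4-dimethylphenyl, so they cannot tell whether the higher number follows from one methyl, the other, or the pair together. They also leave open how this position would respond to an aryl group bearing a methoxy group, an amine or a carboxylic acid in place of methyl.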